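The compounds below may be only part of what the source reports. "The series", "measured", "known", "first", "only" and "open" are said of these compounds alone.

Of the compounds shown here, three sharing one core have been measured in an assay on HEK293 cells for displacement of a labelled ligand from sodium-dependent dopamine transporter (Homo sapiens), read by scintillation proximity assay; a higher number here means a weaker inhibitor, a lower number a stronger inhibitor. Compound 1 `c1ccc(C2CNCCN2c2ccc3[nH]ncc3c2)cc1` gives 200 nM. Compound 2 `COCC1CNCCN1c1ccc2[nH]ncc2c1` gives 501 nM, and compound 3 `CCOCC1CNCCN1c1ccc2[nH]ncc2c1` gives 316 nM. Among these, compound 3 stands second highest of the three numbers, yet both of its neighbours lie within the usual scatter of the measurement: a 1.6-fold higher number from compound 1 to compound 3 (0.20 log units; within the scatter), and a 1.6-fold lower number from compound 2 to compound 3 (0.20 log units; within the scatter). Going by the values given here, on the numbers so far, then, compound 3 cannot be separated from either of the other two.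

Compound 4 `COCCC1CNCCN1c1ccc2[nH]ncc2c1` has the same atoms as compound 3, joined differently: methoxymethyl in place of ethoxy on a saturated chain carbon bound to a saturated ring carbon. The same difference, cut one bond further out, reads ethoxymethyl to 2-methoxyethyl. Among the compounds with values here, no measured step rearranges the chain in this way, so the guidance is indirect. The steps that touch this side chain at all are modest or small: a 2.5-fold higher number from compound 1 to compound 2 (0.40 log units; beyond the scatter), a 1.6-fold higher number from compound 1 to compound 3 (0.20 log units; within the scatter), and a 1.6-fold lower number from compound 2 to compound 3 (0.20 log units; within the scatter). Since the changes confined to the chain itself stayed within the scatter, a step of a 1.3-fold higher number from compound 3 to compound 4 (0.10 log units; within the scatter) is expected for compound 4, that is, no shift beyond the scatter. Compound 4 is therefore estimated at 400 nM, with a likely range from 200 nM to 800 nM.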

Compound 4, inhibition constant: 158 nM
Beside the measured number, compound 4's estimate is 2.5-fold (0.40 log units) above it, outside the stated range (below it).
By their numbers in this assay, from the lowest: compounds 4, 1, 3 and 2 (each within the scatter of the next, the first and the last beyond it).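

Rearranging the same atoms from ethoxymethyl to 2-methoxyethyl gives a 2.0-fold lower number from compound 3 to compound 4 (0.30 log units; within the scatter) in this assay, so at this position moving the oxygen along the chain produces no shift that can be told from repeat-measurement noise. The 2-methoxyethyl chain does give the first clear separation among the chains with an oxygen, a 3.2-fold lower number from compound 2 to compound 4 (0.50 log units; beyond the scatter), whereas the extra carbon of the ethoxymethyl chain gave only a 1.6-fold lower number from compound 2 to compound 3 (0.20 log units; within the scatter), so where the carbon is added may count, although these few steps cannot settle it. The 2-methoxyethyl chain, which has no ring, also cannot be told apart from the phenyl group, with a 1.3-fold lower number from compound 1 to compound 4 (0.10 log units; within the scatter), so a ring at this saturated ring carbon is not needed for a value in this range.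

No supporting evidence is available to explain any of these steps. The compounds shown leave open whether the chain oxygen matters at all, which a plain butyl chain could test, and whether the trend continues to a longer chain such as 3-methoxypropyl or changes with an amine at the chain end.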